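A few compounds are considered here, and "the series" means these few. Any claim that something is new, unique, unknown or untested is made for them only; others in the source may bear on it.

For the measured compounds named here, in a functional assay on KB cells (Homo sapiens) for inhibition, read by sulforhodamine B assay, with a stated time of 48 h (a lower number here means a stronger inhibitor of growth, a higher number a weaker inhibitor of growth), compound 3 `COc1ccc2c(c1)NC(=O)CN2c1nc(NCCCO)nc2ccccc12` gives 4.92 nM and compound 1 `COc1ccc2c(c1)NC(=O)CN2c1nc(COC(C)=O)nc2ccccc12` gives 5.05 nM, so these two share the low end of the three numbers known, while compound 2 `COc1ccc2c(c1)NC(=O)CN2c1nc(OCC2CC2)nc2ccccc12` gives 14.2 nM. Compound 4 `COc1ccc2c(c1)NC(=O)CN2c1nc(NC2CCCC2)nc2ccccc12` keeps the shared core and changes one group on a nitrogen on an aromatic ring: cyclopentyl in place of 3-hydroxypropyl on a nitrogen on an aromatic ring. Going by the values given here, no measured pair makes this exact swap. The closest evidence comes from other group swaps at this place, which gave a 1.0-fold lower number from compound 1 to compound 3 (0.01 log units; within the scatter) and a 2.9-fold lower number from compound 2 to compound 3 (0.46 log units; beyond the scatter). Compound 2 also carries a carbon ring and no hydroxyl, and the second of those steps is the guide here. A modest rise is therefore expected, a 2.2-fold higher number from compound 3 to compound 4 (0.35 log units; beyond the scatter). The estimate for compound 4 is 11 nM, with an expected range of 3.5 nM to 35 nM.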

Compound 4, concentration for 50% growth inhibition: 6.92 nM
Beside the measured number, compound 4's estimate is 1.6-fold (0.20 log units) above it; the measured number falls inside the stated range.
By their numbers in this assay, from the lowest: compounds 3, 1 and 4 (each within the scatter of the next); then compound 2.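

In this assay, cyclopentyl, with no hydroxyl, stands level with 3-hydroxypropyl on this nitrogen, a 1.4-fold higher number from compound 3 to compound 4 (0.15 log units; within the scatter), so a number this low does not depend on that hydroxyl. Compound 4 is also level with the acetoxymethyl compound, a 1.4-fold higher number from compound 1 to compound 4 (0.14 log units; within the scatter). A carbon ring alone therefore does not account for the higher number of compound 2, as a 2.1-fold lower number from compound 2 to compound 4 (0.31 log units; beyond the scatter) shows. No measurement shown explains these results. From the compounds shown here alone, whether a carboxylic acid, a dimethylamino chain or a phenyl ring on this nitrogen would keep the number this low remains open.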